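Compound 4: a small swap in a series at the limit

The source may hold more compounds than are shown below. What is called first, only, known or untested is meant among the compounds shown, and "the series" means these compounds.

In an ADME assay on BJ cells (Homo sapiens) for cytotoxicity, read by MTT assay, with a stated time of 72 h (on this read-out lower numbers stand for stronger inhibition and higher numbers for weaker inhibition), compound 3 `Oc1cccc(CNc2ncnc3c2ncn3C2CCCO2)c1` stands at > 100000 nM as a limit, not a number. Compound 2 `Oc1ccccc1CNc1ncnc2c1ncn2C1CCCO1` gives > 100000 nM as a limit too. Compound 4 `COc1ccccc1CNc1ncnc2c1ncn2C1CCCO1` is still unmeasured: 2-methoxyphenyl replaces 3-hydroxyphenyl on a saturated chain carbon bound to a nitrogen on an aromatic ring, with 2-methoxyphenyl in place of 3-hydroxyphenyl on a saturated chain carbon bound to a nitrogen on an aromatic ring as the count. Among the measured compounds shown here, the one measured step bearing on this is a step that the two limits leave unreadable from compound 2 to compound 3 and offers no size. Compound 1 `COc1ccccc1CNc1ncnc2c1ncn2C1CCCCO1` also carries 2-methoxyphenyl and stands at > 100000 nM as a limit. Given the limit of > 100000 nM in this assay, at which 3 of the 3 values shown sit, as the only reading, no step beyond the scatter is expected in this assay in either direction. The expected step is a number no higher from compound 3 to compound 4 (the limit leaves the size open) as an estimate only. The estimate for compound 4 is 100000 nM with an expected range from 40000 nM to 200000 nM and a report as a limit again is likely.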

Compound 4, half-maximal inhibitory concentration: > 100000 nM
Compound 4 gave a limit, no number (the forecaster's own chance of this, stated with the estimate: 90%); the middle value sits exactly at the limit.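

No step to compound 4 from compound 1, compound 2 or compound 3 can be read in this assay, as all four values are limits: the limit of > 100000 nM in this assay, at which 4 of the 4 values shown sit.

The compounds shown leave open whether any of these groups changes the read-out, and at what concentration, if any, cytotoxicity appears.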